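The source may report more compounds than this note shows. Statements on the series, on what has been measured and on what is new or still open speak of the compounds shown alone.

Working notes on the series in a functional assay on ECa-109 cells (Homo sapiens) for antiproliferative activity, read by MTT assay, with a stated time of 48 h; a lower number here means a stronger inhibitor, a higher number a weaker inhibitor. Compound 1 `Cn1cc(C2=C(c3nn(CCCN4CCCCC4)c4ncccc34)C(=O)N(c3ccc(Cl)cc3)C2=O)c2ccccc21`, with 4-chlorophenyl on the amide-type nitrogen in a ring, gives > 100000 nM, which is a limit of the assay and not a number. Going by the values given here, compound 2 `Cn1cc(C2=C(c3nn(CCCN4CCCCC4)c4ncccc34)C(=O)N(c3cccc4ccccc34)C2=O)c2ccccc21`, with naphthalen-1-yl at that place, gives 1830 nM, the only true number so far. Among the compounds with values here, the single measured step at this place is an at least 54-fold lower number from compound 1 to compound 2 (1.73 log units; beyond the scatter), and it rests on the limit noted in the limit of > 100000 nM in this assay, at which 1 of the 2 values shown sits, so its real size is open.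

Next is compound 3 `Cn1cc(C2=C(c3nn(CCCN4CCCCC4)c4ncccc34)C(=O)N(c3ccccn3)C2=O)c2ccccc21`, which has pyridin-2-yl in place of naphthalen-1-yl on the same nitrogen: pyridin-2-yl in place of naphthalen-1-yl on an amide-type nitrogen in a ring. Like the 4-chlorophenyl of compound 1, the entering group is a single ring. Within the data shown here, the step of an at least 54-fold lower number from compound 1 to compound 2 (1.73 log units; beyond the scatter) is therefore the only guide, and it points to a large move in this assay towards a higher number, with some chance that only a limit is reported. The expected change is an 8.2-fold higher number from compound 2 to compound 3 (0.91 log units; beyond the scatter). Compound 3 is estimated at 15000 nM, with an expected range of 2500 nM to 90000 nM.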

Compound 3, half-maximal inhibitory concentration: 7300 nM
Compound 3: middle estimate off by 2.1-fold (0.31 log units), on the high side; the range from low to high includes it.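

With pyridin-2-yl on the amide-type nitrogen in a ring, the series keeps a true number in this assay, and the step of a 4.0-fold higher number from compound 2 to compound 3 (0.60 log units; beyond the scatter) is only modest, so naphthalen-1-yl is not needed at this position for a measurable value. Compound 3 also carries a single ring, as compound 1 does, yet the step of an at least 13-fold lower number from compound 1 to compound 3 (1.13 log units; beyond the scatter) separates them, so among these three compounds the count of rings in the group on this nitrogen does not set the result, and compound 1 goes against any order by ring count. Compound 1 remains a limit and not a number, so the real size of that step is open, since it rests on that limit: the limit of > 100000 nM in this assay, at which 1 of the 3 values shown sits.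

On these data alone, whether the gap between the two single-ring groups belongs to the chlorine, to the ring nitrogen of pyridin-2-yl or to both stays open, and a plain phenyl would be the group that separates these readings. As far as these compounds go, how pyridin-4-yl or naphthalen-2-yl would read at this place is also open, as is whether the order of the three groups holds with a morpholine in place of the ring amine on the propyl chain of the shared core.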